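This account rests on a few compounds, and the source may have more. Where it says the series, first, only, none or still open, it means among the compounds named here.

Compound 1 `CCCCCCOc1ccc(C(=O)NC2CCCC2(C)C)cc1` is the starting point. In an assay for activation of potassium voltage-gated channel subfamily KQT member 1 (Cavia porcellus) (a lower number here means a stronger inhibitor, a higher number a weaker inhibitor), compound 1 reaches only a limit of the assay, > 30000 nM, not a number. Two further compounds with other cores give a sense of the range: compound 2 `Cc1noc(-c2ccc(C(=O)NCC3CCCC3(C)C)cc2)n1` gives 580 nM; 220 nM (2 entries) in this assay, and compound 3 `CC(C)(C)CCNC(=O)c1ccc(-c2nc(-c3ccccc3)no2)cc1` gives 130 nM. The repeated entries of compound 2, (the several entries of compound 2 in this assay, 580 nM; 220 nM (2 entries)), show how far two measurements of one compound can lie apart.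

Compound 4 `CCCCCCOc1ccc(C(=O)NCCC(C)(C)C)cc1` differs from compound 1 in one place: 3,3-dimethylbutyl in place of 2,2-dimethylcyclopentyl on an amide-type nitrogen. The amide and the core of compound 1 stay unchanged. For the measured compounds named here, no measured pair shows the effect of this exchange on this core. Compound 3 carries the same 3,3-dimethylbutyl on its amide nitrogen, but on a different core, so its value cannot be carried over directly.

The step from compound 1 to compound 4 is expected to be small, a number no higher from compound 1 to compound 4 (the limit leaves the size open), with no clear direction beyond the scatter. Compound 4 is therefore estimated at 30000 nM, within a range from 6000 nM to 120000 nM.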

Compound 4, half-maximal inhibitory concentration: 250 nM
Compound 4: middle estimate off by 120-fold (2.08 log units), on the high side, outside the stated range (below it).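

On this core, the group on the amide nitrogen has a strong effect. In this assay, exchanging the ring-bearing 2,2-dimethylcyclopentyl for the open-chain 3,3-dimethylbutyl, with the rest of the molecule unchanged, gives an at least 120-fold lower number from compound 1 to compound 4 (2.07 log units; beyond the scatter). The value of compound 1, > 30000 nM, is a limit of the assay and not a number, so the true size of this step stays open: the limit of > 30000 nM in this assay, at which 1 of the 4 values shown sits.

The compounds shown do not reveal whether opening the ring matters most or whether the exact shape of the chain does, and a plain cyclopentyl without its two methyl groups or a straight pentyl chain on this core would help to separate the two. They also leave open how a chain ending in an amine or a carboxylic acid would behave at this position.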